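From 3-hydroxypropyl to 1-carboxyethyl on the amide nitrogen

The source may hold more compounds than are shown below. What is called first, only, known or untested is meant among the compounds shown, and "the series" means these compounds.

In a functional assay on BXPC-3 cells (Homo sapiens) for antiproliferative activity, read by MTT assay, with a stated time of 24 h (on this read-out lower numbers stand for stronger inhibition and higher numbers for weaker inhibition), compound 1 (`CCn1c(C(=O)NCCN)ccc1C(CC)(CC)c1ccc(OCS(=O)(=O)c2ccccc2)c(C)c1`) gives 6430 nM and compound 2 (`CCn1c(C(=O)N[C@H](C)CO)ccc1C(CC)(CC)c1ccc(OCS(=O)(=O)c2ccccc2)c(C)c1`) gives 10000 nM as values within the scatter of each other. Compound 3 (`CCn1c(C(=O)NCCCO)ccc1C(CC)(CC)c1ccc(OCS(=O)(=O)c2ccccc2)c(C)c1`) gives 26600 nM and carries the highest number of the three, which makes it the weakest of this small set.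

The next structure is compound 4 (`CCn1c(C(=O)N[C@H](C)C(=O)O)ccc1C(CC)(CC)c1ccc(OCS(=O)(=O)c2ccccc2)c(C)c1`), with 1-carboxyethyl in place of 3-hydroxypropyl on an amide-type nitrogen. All measured steps change this same amide substituent. The first, a 1.6-fold higher number from compound 1 to compound 2 (0.19 log units; within the scatter), stays small, while the other two, a 4.1-fold higher number from compound 1 to compound 3 (0.62 log units; beyond the scatter) and a 2.7-fold higher number from compound 2 to compound 3 (0.42 log units; beyond the scatter), are modest. Among the measured groups, the 1-(hydroxymethyl)ethyl of compound 2 has the name closest to 1-carboxyethyl, so the step to compound 2 is the best guide and points to a lower number than that of compound 3. Among the compounds with values here, no measured compound carries a carboxyl group, so this guide is weak and the range stays wide. The expected step in this assay is a 1.7-fold lower number from compound 3 to compound 4 (0.22 log units; within the scatter) and no clear change beyond the scatter is expected. For compound 4 the estimated value is 16000 nM with an expected range from 5000 nM to 50000 nM in this read-out.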

Compound 4, half-maximal inhibitory concentration: 20100 nM
Beside the measured number, compound 4's estimate is 1.3-fold (0.10 log units) below it; low and high end bracket the measured number.
By their numbers in this assay, from the lowest: compounds 1, 2, 4 and 3 (each within the scatter of the next, the first and the last beyond it).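

In this assay carboxy in place of hydroxymethyl on this amide substituent gives a 2.0-fold higher number from compound 2 to compound 4 (0.30 log units; within the scatter) and 1-carboxyethyl in place of 3-hydroxypropyl gives a 1.3-fold lower number from compound 3 to compound 4 (0.12 log units; within the scatter) and so the only carboxylic acid in the series cannot be told apart from either hydroxyl-bearing substituent on this amide-type nitrogen. Set against the 2-aminoethyl of compound 1, the same group shows a 3.1-fold higher number from compound 1 to compound 4 (0.49 log units; beyond the scatter) and this is the one step to compound 4 that lies beyond the scatter, yet compound 2 sits within the scatter of both compound 1 and compound 4, so the amine and the acid do not form two cleanly separated groups. No measurement that would explain any of these steps is at hand.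

Open, as far as these compounds go, is whether a methyl ester of the 1-carboxyethyl group, or a 2-carboxyethyl chain with the acid further from the amide nitrogen, would read differently from compound 4. Also open, from the compounds shown here alone, is whether a longer amine such as 3-aminopropyl would stay with compound 1, and whether the opposite configuration at the defined stereocentre of 1-carboxyethyl would alter the reading.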